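From oxetan-3-yl to an open trifluoropropyl chain

This account rests on a few compounds, and the source may have more. Where it says the series, first, only, none or still open, it means among the compounds named here.

Compound 1 `CC[C@@H]1C(=O)N(C)c2cnc(-n3ccnc3-c3ccccc3)nc2N1[C@@H]1CCOC1` gives 0%
Compound 2 `CC[C@@H]1C(=O)N(C)c2cnc(-n3ccnc3-c3ccc(F)cc3)nc2N1[C@H]1CCOC1` gives 67%
Compound 3 `CC[C@@H]1C(=O)N(C)c2cnc(-n3ccnc3-c3ccc(F)cc3)nc2N1C1COC1` gives 80%

These values come from an ADME assay on microsomes from liver (Rattus norvegicus) for metabolic stability, with a stated time of 30 min, tested at 1 uM (on this read-out higher numbers stand for a more stable compound and lower numbers for a less stable compound), and place compound 3 highest of the three. Its closest neighbour lies a modest distance away, with the measured step reading a number 13 percentage points higher from compound 2 to compound 3 (beyond the scatter) and lying beyond the scatter. That step put oxetan-3-yl in place of oxolan-3-yl on a nitrogen on an aromatic ring in a ring. Compound 1 sits far lower at 0% on the same scale.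

Compound 4 `CC[C@@H]1C(=O)N(C)c2cnc(-n3ccnc3-c3ccc(F)cc3)nc2N1CCC(F)(F)F` has not yet been measured. It carries 3,3,3-trifluoropropyl in place of oxetan-3-yl on that nitrogen 3,3,3-trifluoropropyl in place of oxetan-3-yl on a nitrogen on an aromatic ring in a ring and so has no ring there. Within the data shown here, only one measured step bears on this place, and a number 13 percentage points higher from compound 2 to compound 3 (beyond the scatter) exchanged one ring for another. It is therefore only a rough guide to size, and no open chain has been measured at this place. A modest fall beyond the scatter is expected, with a number 15 percentage points lower from compound 3 to compound 4 (beyond the scatter) as the estimated step and with considerable uncertainty. For compound 4 the estimate is 65% in an expected range from 40% to 88% in this assay when it is measured.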

Compound 4, percent of the compound remaining: 30%
Compound 4: middle estimate off by 35 percentage points, on the high side, and the stated range ends above it.
By their numbers in this assay, from the lowest: compound 1; then compound 4; then compound 2; then compound 3.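

On this nitrogen, this assay tolerates a change from one ring to another far better than a change from a ring to an open chain. The ring exchange gave only a modest difference, with a number 13 percentage points higher from compound 2 to compound 3 (beyond the scatter) on record, whereas the open chain gave large ones, with a number 50 percentage points lower from compound 3 to compound 4 (beyond the scatter) and a number 37 percentage points lower from compound 2 to compound 4 (beyond the scatter) for the two ring compounds. Among these three compounds with the same core, which all carry the fluorinated phenyl group, the position therefore matters more than the ring exchange alone suggested, and the open 3,3,3-trifluoropropyl chain sits below both oxygen-containing rings. No measured information is available to explain this drop.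

The change removes the ring and the ring oxygen and adds three fluorine atoms all at once, so the compounds shown cannot tell which of these differences goes with the lower number. A plain propyl chain, a cyclobutyl ring or a 2-methoxyethyl chain on this nitrogen would begin to separate these features, and how far the trend holds for other open chains remains undetermined.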